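Swapping the ring next to the nitrogen in a hydroxyphenyl pyridine pair

The compounds below may be only part of what the source reports. "The series", "measured", "known", "first", "only" and "open" are said of these compounds alone.

Compound 2 `Oc1ccc(-c2cc(-c3ccc(Cl)cc3)nc(-c3ccccn3)c2)cc1` gives 21300 nM in a functional assay on HCT-15 cells (Homo sapiens) for cytotoxicity, read by CCK-8 assay and cell counting, with a stated time of 2 days (on this read-out higher numbers stand for weaker inhibition and lower numbers for stronger inhibition), the higher of the two numbers recorded; compound 1 `Oc1ccc(-c2cc(-c3ccco3)nc(-c3ccccc3Cl)c2)cc1` gives 5460 nM in this assay. Compound 3 `Oc1ccc(-c2cc(-c3ccc(Cl)cc3)nc(-c3ccco3)c2)cc1` differs from compound 2 by furan-2-yl in place of pyridin-2-yl on an aromatic carbon. Among the measured compounds shown here, no step between measured compounds isolates this change, so the expectation rests on compound 1, whose furan-2-yl group accompanies 5460 nM. The step from compound 2 to compound 3 is expected as a 2.2-fold lower number from compound 2 to compound 3 (0.35 log units; beyond the scatter), toward a lower number, of a size that may not exceed the scatter. Compound 3 is therefore estimated at 9500 nM, within 3500 nM to 26000 nM.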

Compound 3, half-maximal inhibitory concentration: 7020 nM
Compound 3: middle estimate off by 1.4-fold (0.13 log units), on the high side, and the stated range covers the measured number.
By their numbers in this assay, from the lowest: compounds 1 and 3 (each within the scatter of the next); then compound 2.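

Next to the ring nitrogen, furan-2-yl in place of pyridin-2-yl gives a 3.0-fold lower number from compound 2 to compound 3 (0.48 log units; beyond the scatter) in this assay with the 4-chlorophenyl group unchanged, the first direct reading of this position. With furan-2-yl held, 4-chlorophenyl in place of 2-chlorophenyl gives a 1.3-fold higher number from compound 1 to compound 3 (0.11 log units; within the scatter) and so does not separate the two chlorophenyl groups. Nothing available explains the step at this position.

From the compounds shown here alone, whether the furan-2-yl step carries over to a 2-chlorophenyl partner remains open. Going by these compounds, how an amine or a carboxylic acid would compare at this position also remains open.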